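This account rests on a few compounds, and the source may have more. Where it says the series, first, only, none or still open, it means among the compounds named here.

Measured compounds, antiproliferative read-out:

- compound 1, `OCC(O)Cn1nc2c(Br)c(Br)c(Br)c(Br)c2n1`, in a functional assay on MCF7 cells (Homo sapiens) for antiproliferative activity, read by MTT assay, with a stated time of 48 h, tested at 25 uM (on this read-out higher numbers stand for a weaker effect at the one concentration tested and lower numbers for a stronger effect), compound 1 gives 111%
- compound 2, `OC(CCn1nc2c(Br)c(Br)c(Br)c(Br)c2n1)c1cccc(Cl)c1`, in this assay compound 2 gives 101%

Both numbers sit near the untreated level and within the usual scatter of each other, so neither compound can be separated from the other on this read-out. Compound 2 stands among two numbers whose difference is within the scatter, and nothing in the two values shows a shift from the hydroxypropyl side chain of compound 1 to the aryl-bearing side chain of compound 2.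

Compound 3, `OC(CCn1nc2c(Br)c(Br)c(Br)c(Br)c2n1)c1cccc(Br)c1`, is the next member and has not been measured. It differs from compound 2 by the change (bromo in place of chloro on an aromatic carbon). For the measured compounds named here, since no step between measured compounds bears on this change, the expectation for compound 3 rests only on the fact that the two measured compounds show no effect at the one concentration tested. The step from compound 2 to compound 3 is expected to be a number 2 percentage points higher from compound 2 to compound 3 (within the scatter), that is, none beyond the scatter. Compound 3 is therefore estimated to give 103%, with a range from 90% to 116%.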

Compound 3, a percentage reported as activity, at one concentration (the size of the read-out at that concentration, not a potency): 106%
Beside the measured number, compound 3's estimate is 3 percentage points below it; the measured number falls inside the stated range.
By their numbers in this assay, from the lowest: compounds 2, 3 and 1 (each within the scatter of the next).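

Notes on the 3-chlorophenyl to 3-bromophenyl change: in this assay, bromo in place of chloro on an aromatic carbon, meta to a large group, gives a number 5 percentage points higher from compound 2 to compound 3 (within the scatter) and is the first single-place comparison available in the series. At this place and at the one concentration tested, the chloro and bromo members cannot be told apart, so this exchange of one halogen for the other gives no sign of a stronger effect. No measurement at hand accounts for this result or bears on what lies behind it.

On these data alone, it remains open whether a group of another kind at this same place, such as an amine, a carboxylic acid or a methoxy group, would give a step beyond the scatter on this antiproliferative read-out. The compounds shown also leave open whether a longer chain between the shared core and the hydroxyl-bearing carbon, or a halogen elsewhere on the six-membered aromatic ring, would separate any member from compound 2.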